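The source may hold more compounds than are shown below. What is called first, only, known or untested is meant among the compounds shown, and "the series" means these compounds.

Measured compounds in an ADME assay on RAW264.7 cells (Mus musculus) for cytotoxicity, read by WST assay; on this read-out higher numbers stand for lower toxicity in this test and lower numbers for higher toxicity in this test:
- compound 1 `O=C(c1ccc(CN2C(=O)c3ccccc3S2(=O)=O)cc1)N1CCCCC1`: 69200 nM
- compound 2 `O=C(c1ccc(CN2Cc3ccccc3C2=O)cc1)N1CCCCC1`: reported as a limit, > 100000 nM
- compound 3 `O=C(c1ccc(Cn2oc3ccccc3c2=O)cc1)N1CCCCC1`: 66200 nM

Compound 1 holds the highest of the two numbers in this assay; compound 3 sits within the scatter of it. Compound 2 gives only a limit, (the limit of > 100000 nM in this assay, at which 1 of the 3 values shown sits), not a number.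

Compound 4 `CN(C(=O)OC(C)(C)C)C(=O)c1ccc(CN2C(=O)c3ccccc3S2(=O)=O)cc1` is the untested analogue. It differs from compound 1 by methyl(tert-butoxycarbonyl)amino in place of piperidin-1-yl on a carbonyl carbon. Among the compounds with values here, no measured pair in the set shows this kind of change, so no step size is known for it. Within the data shown here, the shared core is kept and the cytotoxicity numbers so far cluster in one region, so a step of size a 1.0-fold higher number from compound 1 to compound 4 (0.00 log units; within the scatter) is expected, no direction beyond the scatter. Compound 4 is therefore estimated at 70000 nM, with a range from 30000 nM to 150000 nM.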

Compound 4, concentration lethal to 50% of the cells: > 100000 nM
Compound 4 was reported as a limit; the forecaster's own chance of this, stated with the estimate: 35%; middle value at least 1.4-fold (0.15 log units) from the limit.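

Piperidin-1-yl is the first group changed on this carbonyl carbon, and methyl(tert-butoxycarbonyl)amino in its place gives an at least 1.4-fold higher number from compound 1 to compound 4 (0.15 log units; that floor lies within the scatter) in this assay. This place therefore accepts a group with no ring without a lower number in this test. Compound 4 gives a limit, not a number: the limit of > 100000 nM in this assay, at which 2 of the 4 values shown sit.

From the compounds shown here alone, the size of the step beyond its floor stays unknown. Also open, going by these compounds, is whether a primary amine or a carboxylic acid on this carbonyl carbon would move the number, and whether this change behaves alike on the other cores.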